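Dienone series: chloro in place of nitro on the aryl ring

The source may hold more compounds than are shown below. What is called first, only, known or untested is meant among the compounds shown, and "the series" means these compounds.

Compound 1 `O=C(/C=C/c1ccc(Oc2ncnc3ccc(Cl)cc23)cc1)/C=C/c1c(Cl)cccc1Cl` gives 9300 nM in a functional assay on PC-3 cells (Homo sapiens) for inhibition, read by MTT assay, with a stated time of 72 h; on this read-out higher numbers stand for weaker inhibition and lower numbers for stronger inhibition.
Compound 2 `O=C(/C=C/c1ccc(Oc2ncnc3ccc(Cl)cc23)cc1)/C=C/c1ccc(Cl)c([N+](=O)[O-])c1` gives 11800 nM in this assay.

Compound 2 stands at the top of the two numbers shown, but the step of a 1.3-fold higher number from compound 1 to compound 2 (0.10 log units; within the scatter) is within the scatter, so the two are not distinguished. Compound 3 `O=C(/C=C/c1ccc(Oc2ncnc3ccc(Cl)cc23)cc1)/C=C/c1ccc(Cl)c(Cl)c1` differs from compound 2 by chloro in place of nitro on an aromatic carbon. For the measured compounds named here, no measured step covers this exchange; the only measured step, a 1.3-fold higher number from compound 1 to compound 2 (0.10 log units; within the scatter), is small. Compound 3 is therefore expected to move by a 1.2-fold lower number from compound 2 to compound 3 (0.09 log units; within the scatter), nothing beyond the scatter. The estimate for compound 3 in this assay is 9500 nM, ranging from 3500 nM to 26000 nM.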

Compound 3, half-maximal inhibitory concentration: 18800 nM
Beside the measured number, compound 3's estimate is 2.0-fold (0.30 log units) below it; low and high end bracket the measured number.
By their numbers in this assay, from the lowest: compounds 1, 2 and 3 (each within the scatter of the next, the first and the last beyond it).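

In this assay, chloro and nitro on the aromatic carbon ortho to a chloro group are not separated (a 1.6-fold higher number from compound 2 to compound 3 (0.20 log units; within the scatter)). Moving from 2,6-dichlorophenyl to 3,4-dichlorophenyl gives the first modest step beyond the scatter (a 2.0-fold higher number from compound 1 to compound 3 (0.31 log units; beyond the scatter)), so the placement of the two chloro groups may matter more than the chloro-nitro exchange, though this rests on one pair. No available evidence bears on either step.

As far as these compounds go, whether an amine or a carboxylic acid on this aromatic carbon would shift the number remains open. Also open, from the compounds shown here alone, is whether a 3,4-disubstituted ring differs from other patterns beyond these compounds.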